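Series notes: two measured compounds and one to follow

The source may report more compounds than this note shows. Statements on the series, on what has been measured and on what is new or still open speak of the compounds shown alone.

Two compounds of the shared core have been run in a functional assay on HEK293 cells for agonist activity at G-protein coupled receptor 39 (Homo sapiens), read by scintillation proximity assay and inositol phosphate accumulation, with a stated time of 75 min; on this read-out higher numbers stand for an effect only at larger amounts of compound and lower numbers for an effect already at smaller amounts. Compound 1 `Cc1nn(-c2ncnc3nc[nH]c23)c2c1C(C(=O)NCc1ccc(F)cc1)CC(=O)N2` gives 1220 nM in this assay. Compound 2 `Cc1nn(-c2ncnc3nc[nH]c23)c2c1C(OCCn1nccc1C)CC(=O)N2` gives 1620 nM in this assay. Compound 2 stands at the highest of the two numbers, with compound 1 as its nearest neighbour; the two values lie within the scatter of each other, so the data show no order between them.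

Compound 3 `Cc1nn(-c2ncnc3nc[nH]c23)c2c1C(C(=O)N(C)c1nccs1)CC(=O)N2` is the next structure. It differs from compound 2 as follows: a group of 9 heavy atoms (5 carbon, 2 nitrogen, 1 oxygen, 1 sulfur; one five-membered aromatic ring with 2 hetero atoms) in place of a group of 9 heavy atoms (6 carbon, 2 nitrogen, 1 oxygen; one five-membered aromatic ring with 2 hetero atoms), on a saturated ring carbon. Going by the values given here, no pair of measured compounds differs by this same change, so there is no measured step to lean on. Among the compounds with values here, the only comparison at hand is compound 1, whose value 1220 nM sits within the scatter of compound 2; both readings lie close together although different groups sit on the saturated ring carbon, which argues for a modest step at most. The expected step from compound 2 to compound 3 is a 1.2-fold lower number from compound 2 to compound 3 (0.06 log units; within the scatter), not beyond the scatter in either direction. Compound 3 is estimated at 1400 nM, with a range from 500 nM to 4500 nM.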

Compound 3, half-maximal effective concentration: 3300 nM
Compound 3: the middle estimate sits 2.4-fold (0.37 log units) below what was measured; the measured number falls inside the stated range.
By their numbers in this assay, from the lowest: compounds 1 and 2 (each within the scatter of the next); then compound 3.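

Groups on the saturated ring carbon now separate in this assay in a way the first two compounds, within the scatter of each other, did not show: the entry of methyl(1,3-thiazol-2-yl)carbamoyl brings a 2.0-fold higher number from compound 2 to compound 3 (0.31 log units; beyond the scatter) on this position. The leaving and entering groups count the same heavy atoms, hydrogen-bond donors and acceptors, so these counts alone do not set the number here. On the carbonyl carbon, methyl(1,3-thiazol-2-yl)amino in place of (4-fluorobenzyl)amino brings a 2.7-fold higher number from compound 1 to compound 3 (0.43 log units; beyond the scatter) with the rest of the structure unchanged, and no measured evidence yet bears on why either step occurs.

Whether the higher number goes with the methyl or with the 1,3-thiazol-2-yl ring of the entering group stays open, as the compounds shown do not separate the two. Also open, going by these compounds, is how a primary amine or a carboxylic acid on the saturated ring carbon would read, and whether any group there gives a number lower than those of compound 1 and compound 2.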